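A few compounds are considered here, and "the series" means these few. Any claim that something is new, unique, unknown or untested is made for them only; others in the source may bear on it.

Measured so far:
- compound 1 `Oc1ccc(-c2cc(-c3cccc(O)c3)cc(-c3cccc(O)c3)n2)cc1`: 3920 nM
- compound 2 `Oc1ccc(-c2cc(-c3cccc(O)c3)cc(-c3ccccc3O)n2)cc1`: 50000 nM

In a functional assay on T47D cells (Homo sapiens) for cytotoxicity, read by CCK-8 assay, with a stated time of 4 days (on this read-out higher numbers stand for weaker inhibition and lower numbers for stronger inhibition), compound 2 has the higher of the two numbers, with 50000 nM, and so shows the weaker inhibition. Its nearest neighbour is compound 1, which gives 3920 nM.

Compound 3 `Oc1ccc(-c2cc(-c3ccc(O)cc3)nc(-c3ccccc3O)c2)cc1` has not yet been measured. It has 4-hydroxyphenyl in place of the 3-hydroxyphenyl of compound 2, on an aromatic carbon opposite the ring nitrogen (4-hydroxyphenyl in place of 3-hydroxyphenyl on an aromatic carbon). The 2-hydroxyphenyl group stays.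

Among the measured compounds shown here, only one measured step bears on this change, and it is a large one: a 13-fold higher number from compound 1 to compound 2 (1.11 log units; beyond the scatter). It came from exchanging one hydroxyphenyl group for another, but at a different place, so it shows that such an exchange can matter and gives only loose guidance on size and direction here. For the measured compounds named here, no measured compound isolates the 4-hydroxyphenyl change itself. A modest step toward stronger inhibition is therefore expected, with wide uncertainty, and the expected step is a 2.5-fold lower number from compound 2 to compound 3 (0.40 log units; beyond the scatter). For compound 3 the estimate is 20000 nM, with an expected range from 5000 nM to 60000 nM.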

Compound 3, half-maximal inhibitory concentration: 50000 nM
Beside the measured number, compound 3's estimate is 2.5-fold (0.40 log units) below it; measured number inside the range.
By their numbers in this assay, from the lowest: compound 1; then compounds 2 and 3 (each within the scatter of the next).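

In this assay, with the 2-hydroxyphenyl group kept, 4-hydroxyphenyl in place of 3-hydroxyphenyl on the aromatic carbon opposite the ring nitrogen gives no change at the digits printed from compound 2 to compound 3 (within the scatter), so at this position the two hydroxyphenyl groups cannot be told apart in this background. Among the compounds shown here, the only earlier step, 2-hydroxyphenyl in place of 3-hydroxyphenyl at another place, gave a 13-fold higher number from compound 1 to compound 2 (1.11 log units; beyond the scatter), which shows that exchanging one hydroxyphenyl group for another does not have the same size of effect at every place on the shared core. Nothing available accounts for the lack of a difference at this position.

The compounds shown leave open whether the same exchange would also make no difference in the background of compound 1, where the 3-hydroxyphenyl group takes the place of the 2-hydroxyphenyl group and the number is much lower. They also leave open what a methoxy group, an amine or a carboxylic acid would do in place of the hydroxyl group on the ring at this position.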